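The compounds below may be only part of what the source reports. "The series", "measured", "known", "first", "only" and "open" are said of these compounds alone.

Measured compounds in the series:

Compound 1 `CCOC(=O)CSc1nnc(C)n1N1C(=O)c2ccccc2C1=O` gives in a functional assay on MKN-45 cells (Homo sapiens) for cytotoxicity, read by MTT assay, with a stated time of 48 h (a higher number here means a weaker inhibitor, a lower number a stronger inhibitor), only a limit, > 200000 nM.
Compound 2 `Cc1nnc(SCC(=O)c2ccccc2)n1N1C(=O)c2ccccc2C1=O` gives in this assay only a limit, > 200000 nM.
Compound 3 `C=CCSc1nnc(CC)n1N1C(=O)c2ccccc2C1=O` gives in this assay only a limit, > 200000 nM.

Compound 3 therefore stands at the limit of > 200000 nM in this assay, at which 3 of the 3 values shown sit, together with every other value shown, so its place among the three cannot be ranked. For the measured compounds named here, the one step between measured neighbours, a step that the two limits leave unreadable from compound 1 to compound 2, runs between two limits and gives no readable size.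

Compound 4 `CCc1nnc(SCC(=O)c2ccc(Cl)cc2)n1N1C(=O)c2ccccc2C1=O` differs from compound 3 by (4-chlorophenyl)carbonyl in place of vinyl on a saturated chain carbon bound to a sulfur. Going by the values given here, compound 2 already carries a phenylcarbonyl on the same chain and sits at the limit, and no measured step shows any movement in this assay that could be read. Nothing in the data points to a step beyond the scatter in either direction, and the most likely outcome is again a limit. Compound 4 is expected to give 250000 nM, within 60000 nM to 1000000 nM. The step from compound 3 to compound 4 is estimated at a step that the limit leaves unreadable from compound 3 to compound 4, which is no change beyond the scatter.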

Compound 4, half-maximal inhibitory concentration: > 200000 nM
Compound 4: a limit, no number; the forecaster's own chance of this, stated with the estimate: 80%; the middle value does not contradict the limit.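

Compound 4 also gives only a limit in this assay, so no step from compound 3 to compound 4 can be read: the limit of > 200000 nM in this assay, at which 4 of the 4 values shown sit.

The compounds shown leave open whether any change on the shared core would give a readable value in this assay.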